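A Sulfonyl Chain in Place of Ethoxy on the Shared Core

This account rests on a few compounds, and the source may have more. Where it says the series, first, only, none or still open, it means among the compounds named here.

Compound 1 `CCOCC12CCC(c3nnc(-c4ccccc4C(F)(F)F)n3C)(CC1)CC2` is tested in an assay on CHO-K1 cells for inhibition of 11-beta-hydroxysteroid dehydrogenase type 2 (Mus musculus), read by scintillation proximity assay (on this read-out higher numbers stand for weaker inhibition and lower numbers for stronger inhibition), where compound 1 gives > 4000 nM, a limit of the assay and not a number. Compound 2 `CC(O)CCCC12CCC(c3nnc(-c4ccccc4C(F)(F)F)n3C)(CC1)CC2` gives > 4000 nM in this assay, again a limit. Compound 3 `Cn1c(-c2ccccc2C(F)(F)F)nnc1C12CCC(CNS(C)(=O)=O)(CC1)CC2` gives > 4000 nM in this assay, also a limit. The three measured steps, a step that the two limits leave unreadable from compound 1 to compound 2, a step that the two limits leave unreadable from compound 1 to compound 3 and a step that the two limits leave unreadable from compound 2 to compound 3, therefore show no readable size, and the whole picture is summed up by the limit of > 4000 nM in this assay, at which 3 of the 3 values shown sit.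

Compound 4 `Cn1c(-c2ccccc2C(F)(F)F)nnc1C12CCC(CCS(=O)(=O)C(C)(C)C)(CC1)CC2` differs from compound 1 by ((tert-butyl)sulfonyl)methyl in place of ethoxy on a saturated chain carbon bound to a saturated ring carbon. Within the data shown here, none of the measured steps bears on this change in a readable way, since each begins and ends at the same limit; the measured compounds give no step beyond the scatter in any direction to carry over. Compound 4 is therefore expected to behave like its neighbours, with an estimated step that the limit leaves unreadable from compound 1 to compound 4. The estimate for compound 4 in this assay is 8000 nM, within a range from 2000 nM to 40000 nM, and most probably the assay will once more report only a limit.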

Compound 4, half-maximal inhibitory concentration: > 4000 nM
Compound 4: a limit, no number; the forecaster's own chance of this, stated with the estimate: 80%; the middle value does not contradict the limit.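

The steps linking compound 4 to compound 1, compound 2 and compound 3 cannot be read in this assay, since each joins two limits: the limit of > 4000 nM in this assay, at which 4 of the 4 values shown sit.

The compounds shown leave open how strongly any of them inhibits the enzyme, and whether any of these chains on the shared core changes that.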